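Working notes: from compound 3 to compound 4

A few compounds are considered here, and "the series" means these few. Any claim that something is new, unique, unknown or untested is made for them only; others in the source may bear on it.

Measured so far in a functional assay, read by WST assay; on this read-out higher numbers stand for weaker inhibition and lower numbers for stronger inhibition
- compound 1 `CC1(C)OC(=O)[C@@]2(C=C[C@@H](O)[C@H](O)C2)O1` gives > 100 ug/mL
- compound 2 `CC1(C)OC(=O)[C@@]2(C=C[C@@H](O)[C@H](OC(=O)/C=C/c3ccc(O)c(O)c3)C2)O1` gives 1.5 ug/mL
- compound 3 `CC1(C)OC(=O)[C@@]2(C=C[C@@H](OC(=O)/C=C/c3ccc(O)c(O)c3)[C@H](O)C2)O1` gives 1.3 ug/mL

The value of compound 1 is a limit of the assay, not a number. Within the data shown here, compound 3 stands at 1.3 ug/mL within the scatter of compound 2 at 1.5 ug/mL on this read-out, and these are the only two true numbers.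

Compound 4 `CC1(C)OC(=O)[C@@]2(C=C[C@@H](OC(=O)/C=C/c3ccc(O)c(O)c3)[C@H](OC(=O)/C=C/c3ccc(O)c(O)c3)C2)O1` is the next to be read. The change from compound 3 is (2-(3,4-dihydroxyphenyl)ethenyl)carbonyl in place of hydrogen on an oxygen on a saturated carbon in the form of (2-(3,4-dihydroxyphenyl)ethenyl)carbonyl in place of hydrogen on an oxygen on a saturated carbon.

Among the measured compounds shown here, no measured step covers this change, so the expectation is only loose. No shift beyond the scatter is expected in this assay and the direction is left open. The estimated move is a 1.3-fold lower number from compound 3 to compound 4 (0.11 log units; within the scatter) on this basis. Compound 4 is expected at 1 ug/mL with an estimated range of 0.4 ug/mL to 3 ug/mL in this assay.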

Compound 4, half-maximal inhibitory concentration: 2 ug/mL
Compound 4: the middle estimate sits 2.0-fold (0.30 log units) below what was measured, within the range that was stated.
By their numbers in this assay, from the lowest: compounds 3, 2 and 4 (each within the scatter of the next). At a limit, above all of these: compound 1.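

In this assay, a second (2-(3,4-dihydroxyphenyl)ethenyl)carbonyl on an oxygen on a saturated carbon gives a 1.5-fold higher number from compound 3 to compound 4 (0.19 log units; within the scatter) and a 1.3-fold higher number from compound 2 to compound 4 (0.12 log units; within the scatter). Compound 2, compound 3 and compound 4 therefore cannot be told apart on this read-out: with the group on either oxygen or on both, the numbers stay within the scatter, and the second group brings no measurable gain. Compound 1 carries no such group, and its reading is a limit, not a number: the limit of > 100 ug/mL in this assay, at which 1 of the 4 values shown sits.

Open, as far as these compounds go, is whether a plain phenyl in place of the 3,4-dihydroxyphenyl, or an amide in place of the link through oxygen, would keep a reading in this range. Also open is what the shared core contributes, since all the compounds shown carry it unchanged.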